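Amide variation and liver microsomal clearance in a thioether series

A few compounds are considered here, and "the series" means these few. Any claim that something is new, unique, unknown or untested is made for them only; others in the source may bear on it.

Compound 1, `CC1CCCN1C(=O)CCSc1nc2cc(Cl)ccc2o1`: 8.5 mL/min/g
Compound 2, `O=C(CCSc1nc2ccccc2o1)N1CCCC1`: 5.1 mL/min/g

In an ADME assay on microsomes from liver (Homo sapiens) for metabolic stability, read by LC-MS, using NADPH, with a stated time of 45 min, tested at 0.5 uM (a higher number here means faster removal of the compound, a lower number slower removal), compound 1 gives 8.5 mL/min/g and compound 2 gives 5.1 mL/min/g. Among the measured compounds shown here, compound 1 carries the larger of the two numbers, but its gap to compound 2 lies within the usual scatter, so the two are not separated, and the two structures differ in more than one place, so no single step between them is available.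

Compound 3, `CN1CCN(C(=O)CCSc2nc3cc(Cl)ccc3o2)CC1`, is not yet measured. It differs from compound 1 in one place: 4-methylpiperazin-1-yl in place of 2-methylpyrrolidin-1-yl on a carbonyl carbon

For the measured compounds named here, with no measured step of this kind to lean on, the expectation is a modest downward movement in this assay, one that may well stay within the scatter. Compound 3 is expected to give about 6 mL/min/g, with a range from 3 mL/min/g to 12 mL/min/g. The step of a 1.4-fold lower number from compound 1 to compound 3 (0.15 log units; within the scatter) implied by that estimate is expected to be small.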

Compound 3, intrinsic clearance in a liver preparation (reported as CLH), per the amount of preparation that the assay uses: 1.5 mL/min/g
For compound 3 the middle estimate is 4.0-fold (0.60 log units) above the measured one; measured number below the stated range.
By their numbers in this assay, from the lowest: compound 3; then compounds 2 and 1 (each within the scatter of the next).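

In this assay the amide position proves responsive: 4-methylpiperazin-1-yl in place of 2-methylpyrrolidin-1-yl on a carbonyl carbon gives a 5.7-fold lower number from compound 1 to compound 3 (0.75 log units; beyond the scatter) and so moves the number beyond the scatter, which the pair of compound 1 and compound 2 could not show. The change alters ring size and the hetero atoms of the ring together, so this single step does not assign the movement to either feature. No measurement at hand explains the step.

From the compounds shown here alone, whether the ring size, the second ring nitrogen or its methyl group carries the step remains open, and piperidin-1-yl or morpholin-4-yl on the same carbonyl carbon would help to separate them. Also open, going by these compounds, is whether 4-methylpiperazin-1-yl gives a similar step on the core of compound 2.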